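This account rests on a few compounds, and the source may have more. Where it says the series, first, only, none or still open, it means among the compounds named here.

Measured compounds:
Compound 1 `C[C@H](NC(=O)CN(c1nc(Cl)nc2[nH]cnc12)C1CC1)C(=O)OCc1ccccc1` — 64.3%
Compound 2 `O=C(CN(c1nc(Cl)nc2[nH]cnc12)C1CC1)NCC(=O)OCc1ccccc1` — 41.9%
Compound 3 `C[C@@H](O)[C@H](NC(=O)CN(c1ncnc2c1ncn2C1CCCCO1)C1CC1)C(=O)OCc1ccccc1` — 28.4%

All three were run in a functional assay on the whole organism (Tail, strain ICR) with Mus musculus as the target, in the tail flick test, with a stated time of 60 min, at a dose of 25 umol/kg by the oral route; on this read-out higher numbers stand for a stronger effect at the one dose given and lower numbers for a weaker effect. Compound 1 and compound 2 share one core and differ in a single place: hydrogen in place of methyl on a saturated chain carbon bound to an amide-type nitrogen and a carbonyl carbon. On this change the read-out moved by a number 22.4 percentage points lower from compound 1 to compound 2 (beyond the scatter). Compound 3 carries a different core; the difference between the two cores is not broken down here. Of the three measured numbers, compound 3 stands lowest, its value lying beyond the scatter from each of the other two.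

Compound 4 `O=C(CN(c1ncnc2c1ncn2C1CCCCO1)C1CC1)N[C@@H](CO)C(=O)OCc1ccccc1` is not yet measured. It differs from compound 3 by hydrogen in place of methyl on a saturated chain carbon bound to an oxygen on a saturated carbon and a saturated chain carbon. This is the same kind of change as that from compound 1 to compound 2, but not the same: there the place was on a saturated chain carbon bound to an amide-type nitrogen and a carbonyl carbon, here it is on a saturated chain carbon bound to an oxygen on a saturated carbon and a saturated chain carbon.

For the measured compounds named here, for compound 4 the step from compound 3 is expected to be a number 10.4 percentage points lower from compound 3 to compound 4 (beyond the scatter), in the same direction as the one measured from compound 1 to compound 2 but smaller, because the earlier step of a number 22.4 percentage points lower from compound 1 to compound 2 (beyond the scatter) sits at a different place and only one example of the change exists. Compound 4 is estimated at 18%, within 5% to 35%.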

Compound 4, a percentage reported as activity, at one dose (the size of the read-out at that dose, not a potency): 46.7%
Estimate against measurement, compound 4: 28.7 percentage points below, and the stated range ends below it.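

In this assay, hydrogen in place of methyl gives a number 18.3 percentage points higher from compound 3 to compound 4 (beyond the scatter), so the direction of the earlier step does not carry over to the core of compound 3. Set side by side, the two steps point in opposite directions and the gap between them is larger than the scatter: the same change on two cores in this assay, a number 22.4 percentage points lower (beyond the scatter) from compound 1 to compound 2 and a number 18.3 percentage points higher (beyond the scatter) from compound 3 to compound 4, 40.7 percentage points apart, beyond the scatter of two such steps

This does not show what sets the sign, since the two steps differ in core and also in place: the first lies on a saturated chain carbon bound to an amide-type nitrogen and a carbonyl carbon, the second on a saturated chain carbon bound to an oxygen on a saturated carbon and a saturated chain carbon, and with one example of each the two differences cannot be separated.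

Still open, on these data alone, is how the 1-hydroxyethyl to hydroxymethyl change reads on the core of compound 1, where it would stand apart from any change of core. Also open, as far as these compounds go, is whether the higher number on the core of compound 3 holds when the hydroxymethyl gives way to an aminomethyl, a carboxylic acid or a longer chain.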